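Swapping Propyl for Pyrimidinyl on an Amide-Type Nitrogen

The source may report more compounds than this note shows. Statements on the series, on what has been measured and on what is new or still open speak of the compounds shown alone.

Going by the values given here, compound 3 `CCCNC(=O)Nc1cc(/C(=N/O)Nc2ccc(F)c(Br)c2)ccc1N(CC(C)C)CC(C)C` gives 2900 nM in an assay on isolated protein for inhibition of Indoleamine 2,3-dioxygenase 1 (Homo sapiens) (a lower number here means a stronger inhibitor, a higher number a weaker inhibitor), the higher of the two numbers measured so far. Compound 2 `CC(C)CN(CC(C)C)c1ccc(/C(=N/O)Nc2ccc(F)c(Br)c2)cc1NC(=O)Nc1ccc(Cl)cc1` gives 1490 nM in this assay, and the step of a 1.9-fold higher number from compound 2 to compound 3 (0.29 log units; within the scatter) stays within the scatter. Compound 1 `CC(C)CN(CC(C)C)c1ccc(/C(=N/O)Nc2ccc(F)c(Br)c2)cc1NC(=O)NC1CCCCC1` reaches only a limit, > 3000 nM, marked by the limit of > 3000 nM in this assay, at which 1 of the 3 values shown sits. Compound 4 `CC(C)CN(CC(C)C)c1ccc(/C(=N/O)Nc2ccc(F)c(Br)c2)cc1NC(=O)Nc1cncnc1` differs from compound 3 by pyrimidin-5-yl in place of propyl on an amide-type nitrogen. Among the compounds with values here, two measured steps bear on this change: the reverse of a 1.9-fold higher number from compound 2 to compound 3 (0.29 log units; within the scatter), an aromatic ring replacing propyl, and an at least 2.0-fold lower number from compound 1 to compound 2 (0.30 log units; that floor lies within the scatter), an aromatic ring replacing a saturated ring; neither went clearly beyond the scatter. A small drop is therefore expected for a 1.5-fold lower number from compound 3 to compound 4 (0.16 log units; within the scatter), not reliably beyond the scatter. Compound 4 is expected to give 2000 nM, within 700 nM to 6000 nM.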

Compound 4, half-maximal inhibitory concentration: > 3000 nM
Compound 4 was reported as a limit (the forecaster's own chance of this, stated with the estimate: 25%); middle value at least 1.5-fold (0.17 log units) away from the limit.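

Compound 4 sits at a limit of the assay, as compound 1 does, so an aromatic ring on this amide-type nitrogen does not by itself keep the value readable: the limit of > 3000 nM in this assay, at which 2 of the 4 values shown sit. The two readable steps, an at least 1.0-fold higher number from compound 3 to compound 4 (0.01 log units; that floor lies within the scatter) and an at least 2.0-fold higher number from compound 2 to compound 4 (0.30 log units; that floor lies within the scatter), give only floors, so pyrimidin-5-yl cannot be ranked against propyl or 4-chlorophenyl. The step between the two limits cannot be read.

Still open, from the compounds shown here alone, is whether an unsubstituted phenyl ring or a longer chain such as hexyl on this nitrogen would move the value clearly beyond the scatter.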